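A few compounds are considered here, and "the series" means these few. Any claim that something is new, unique, unknown or untested is made for them only; others in the source may bear on it.

Measured so far:
compound 1 `O=C(Nc1ccc(Oc2ccnc3[nH]ccc23)cc1)c1cc(-c2ccc(Br)cc2)ncn1`: in a functional assay on A549 cells (Homo sapiens) for cytotoxicity, read by MTT assay, with a stated time of 72 h (on this read-out lower numbers stand for stronger inhibition and higher numbers for weaker inhibition), compound 1 gives 9870 nM.
compound 2 `O=C(Nc1ccc(Oc2ccnc3[nH]ccc23)c(F)c1)c1cc(-c2ccc(C(F)(F)F)cc2)ncn1`: in this assay compound 2 gives 2220 nM.

Compound 2 stands at the lowest of the two numbers; the nearest is compound 1, whose number is higher by a margin beyond the usual scatter. Compound 1 and compound 2 differ in two places at once (a fluoro group present only in compound 2, and bromo in compound 1 where compound 2 carries trifluoromethyl), so no single step can be read from that pair, only the two values themselves.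

Compound 3 `O=C(Nc1ccc(Oc2ccnc3[nH]ccc23)c(F)c1)c1cc(-c2ccc(Br)cc2)ncn1` is not yet measured. It differs from compound 2 in one place: bromo in place of trifluoromethyl on an aromatic carbon. Compound 3 thus keeps the fluoro group of compound 2 and takes the bromo of compound 1. Among the measured compounds shown here, with no single-change step available, the expectation rests on the two values: compound 1, which carries the same bromo, gives 9870 nM, while compound 2 gives 2220 nM. The expected step is a 2.0-fold higher number from compound 2 to compound 3 (0.31 log units; beyond the scatter), towards a higher number, and whether it clears the scatter is uncertain. For compound 3 the estimate is 4500 nM, with a range from 1500 nM to 13000 nM.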

Compound 3, half-maximal inhibitory concentration: 6980 nM
Estimate against measurement, compound 3: 1.6-fold (0.19 log units) below, and the stated range covers the measured number.
By their numbers in this assay, from the lowest: compound 2; then compounds 3 and 1 (each within the scatter of the next).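

In this assay, among the compounds shown here, with the fluoro group held in place, the exchange at the aromatic carbon para to a large group gives a 3.1-fold higher number from compound 2 to compound 3 (0.50 log units; beyond the scatter), which makes this the first single change to clear the scatter and shows that the read-out distinguishes 4-(trifluoromethyl)phenyl from 4-bromophenyl in this setting. For the compounds shown here, the fluoro group, read with bromo fixed, gives a 1.4-fold lower number from compound 1 to compound 3 (0.15 log units; within the scatter), so on this background its presence cannot be told apart from repeat variation, and the substituent on the outer phenyl is the only one of the two changes with a readable step so far. Nothing shown here accounts for the difference between trifluoromethyl and bromo or says what lies behind it.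

Going by these compounds alone, whether the fluoro group would read the same way alongside trifluoromethyl as it does alongside bromo stays open, since the single step available for it comes from the bromo pair. From the compounds shown here alone, how a nitrile, a methoxy group or an amine at the same aromatic carbon would compare with bromo and trifluoromethyl also remains open.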